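An Ester Side Chain Tried on a Second Core

The source may report more compounds than this note shows. Statements on the series, on what has been measured and on what is new or still open speak of the compounds shown alone.

Of the compounds shown here, three have so far been measured in an assay on a protein complex for inhibition of CDK8/Cyclin C (Homo sapiens), with a stated time of 1 h, tested at 10 uM; a higher number here means more inhibition at the concentration tested (going by the name of the read-out), a lower number less inhibition. Compound 1 `CCOC(=O)/C=C/c1ccncc1-c1ccc2c(ccn2C)c1` gives 100% in this assay. Compound 2 `CNC(=O)CCc1ccncc1-c1ccc2ccccc2c1` gives 100% in this assay, and compound 3 `NC(=O)/C=C/c1ccncc1Br` gives 81% in this assay. Compound 2 stands level with compound 1 at the digits shown, and the two together are the highest of the three numbers; the gap between them lies within the usual scatter, so no order can be read from it. Compound 3 lies lower than compound 2, and that gap is beyond the scatter.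

The next compound, compound 4 `CCOC(=O)/C=C/c1ccncc1-c1ccc2ccccc2c1`, keeps the core of compound 2 and alters one group only: 2-(ethoxycarbonyl)ethenyl in place of 2-(methylcarbamoyl)ethyl on an aromatic carbon. Going by the values given here, the chain that enters is the one compound 1 already carries on its own core, where compound 1 gives 100%. Among the compounds with values here, no measured pair shows this exact exchange, so the step must be judged from the two parents. Because compound 1 gives 100% and compound 2 gives 100%, the step of a number 3 percentage points lower from compound 2 to compound 4 (within the scatter) is expected to be none beyond the scatter. Compound 4 is therefore estimated at 97%, with a range from 82% to 100%.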

Compound 4, a percentage reported as inhibition, at one concentration (the size of the read-out at that concentration, not a potency): 102%
Compound 4: the middle estimate sits 5 percentage points below what was measured; measured number above the stated range.
By their numbers in this assay, from the lowest: compound 3; then compounds 1, 2 and 4 (each within the scatter of the next).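

In this assay, putting 2-(ethoxycarbonyl)ethenyl in place of 2-(methylcarbamoyl)ethyl on this aromatic carbon, opposite the ring nitrogen, gives a number 2 percentage points higher from compound 2 to compound 4 (within the scatter) and so shows that, on this core and at this one concentration, the position takes the ester chain as well as the amide chain. The exchange removes the amide hydrogen, the one hydrogen-bond donor of the chain, and adds a second double bond outside the aromatic rings, yet neither difference shows up in this read-out. No measurement at hand explains this outcome.

A percentage at one concentration is a reading of size and not a potency, so the two chains may still differ in strength at lower concentrations, which this single step cannot reveal. Going by these compounds, it also remains open whether a free carboxylic acid, an amine or a longer chain on this same carbon would hold the inhibition at this level, or whether only chains that end in a carbonyl group do so.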